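Chloro for Nitro on the Fused Ring of Compound 3

A few compounds are considered here, and "the series" means these few. Any claim that something is new, unique, unknown or untested is made for them only; others in the source may bear on it.

The shared core carries a chlorophenyl-bearing heterocycle on one side and a fused bicyclic on the other. Compound 2 `Fc1ccc2[nH]c(-c3nc(-c4ccc(Cl)cc4)no3)cc2c1` carries a fluoro on that fused ring; in a functional assay on MCF7 cells (Homo sapiens) for antiproliferative activity, read by WST assay, with a stated time of 72 h (a lower number here means a stronger inhibitor, a higher number a weaker inhibitor), compound 2 reaches only a limit, > 50000 nM. Compound 3 `O=[N+]([O-])c1ccc2[nH]c(-c3nc(-c4ccc(Cl)cc4)no3)cc2c1` carries a nitro in its place; in this assay compound 3 also reaches only a limit, > 50000 nM. The step that the two limits leave unreadable from compound 2 to compound 3 therefore cannot be read, and the limit of > 50000 nM in this assay, at which 2 of the 3 values shown sit, holds both of these values. Compound 1 `Cc1noc(-c2cc3cc(Cl)ccc3[nH]2)n1`, with a methyl on the heterocycle and a chloro on the fused ring, gives 34400 nM in this assay.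

Compound 4 `Clc1ccc(-c2noc(-c3cc4cc(Cl)ccc4[nH]3)n2)cc1` differs from compound 3 in one place: chloro in place of nitro on an aromatic carbon. Among the measured compounds shown here, no measured step describes this exchange, and the step from compound 2 to compound 3 is unreadable. Compound 1, which carries the same chloro on the fused ring, stays weak. Compound 4 is therefore expected near the limit, with an at least 1.1-fold lower number from compound 3 to compound 4 (0.04 log units; that floor lies within the scatter) as a guess rather than a reading. The estimate for compound 4 is 45000 nM, between 15000 nM and 150000 nM.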

Compound 4, half-maximal inhibitory concentration: > 50000 nM
Compound 4 ended at the assay's limit (the forecaster's own chance of this, stated with the estimate: 55%); middle value at least 1.1-fold (0.04 log units) from the limit.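

Chloro now joins fluoro and nitro at this position on the fused ring, and with chloro compound 4 also stays at a limit, so none of the three groups brings a measurable value on this core: the limit of > 50000 nM in this assay, at which 3 of the 4 values shown sit.

Each of the steps among compound 2, compound 3 and compound 4 joins two limits, and none of them can be read.

Among the compounds shown here, the only readable exchange keeps the chloro on the fused ring and puts 4-chlorophenyl in place of methyl, which gives an at least 1.4-fold higher number from compound 1 to compound 4 (0.16 log units; that floor lies within the scatter), so even its direction is not settled beyond the scatter.

Going by these compounds, whether an amine or a carboxylic acid at this position would bring the 4-chlorophenyl series off the limit remains open. So does how a longer chain in place of 4-chlorophenyl would compare with compound 1.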